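This account rests on a few compounds, and the source may have more. Where it says the series, first, only, none or still open, it means among the compounds named here.

Working notes on the series in a functional assay on OVCAR-4 cells (Homo sapiens) for inhibition, read by sulforhodamine B assay, with a stated time of 48 h; on this read-out higher numbers stand for weaker inhibition of growth and lower numbers for stronger inhibition of growth.

Compound 1 `CN1CCN(CCCOc2cccc3nc(Nc4ccc(F)c(F)c4)ccc23)CC1` gives 6420 nM in this assay. For the measured compounds named here, compound 2 `CN1CCN(CCCOc2cccc3nc(Nc4cccc(Cl)c4)ccc23)CC1` gives 1940 nM, the lowest of the two numbers so far; the nearest is compound 1, and the step of a 3.3-fold lower number from compound 1 to compound 2 (0.52 log units; beyond the scatter) lies beyond the scatter.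

Compound 3 `CN1CCN(CCCOc2cccc3nc(Nc4ccc(Cl)c(C(F)(F)F)c4)ccc23)CC1` has not been measured. Its change from compound 2 is 4-chloro-3-(trifluoromethyl)phenyl in place of 3-chlorophenyl on a nitrogen on an aromatic ring. Going by the values given here, only the step from compound 1 to compound 2 touches the same position on the aromatic nitrogen, and that step, a 3.3-fold lower number from compound 1 to compound 2 (0.52 log units; beyond the scatter), was modest; it swapped one halogenated phenyl for another, but no measured pair shows a 4-chloro-3-(trifluoromethyl)phenyl, so it bears on this step only loosely.

On that basis the step of a 1.3-fold lower number from compound 2 to compound 3 (0.11 log units; within the scatter) is expected to be small, with no direction claimed beyond the scatter. Compound 3 is therefore estimated at 1500 nM, with a range from 450 nM to 5000 nM.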

Compound 3, concentration for 50% growth inhibition: 2730 nM
Compound 3: middle estimate off by 1.8-fold (0.26 log units), on the low side; low and high end bracket the measured number.
By their numbers in this assay, from the lowest: compounds 2 and 3 (each within the scatter of the next); then compound 1.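

On the nitrogen on an aromatic ring, 4-chloro-3-(trifluoromethyl)phenyl and 3-chlorophenyl are not separated in this assay: the step is a 1.4-fold higher number from compound 2 to compound 3 (0.15 log units; within the scatter), so the added trifluoromethyl and the shift in chlorine placement together leave the read-out within the scatter. Against 3,4-difluorophenyl the new group reads in the same direction as 3-chlorophenyl, with a 2.4-fold lower number from compound 1 to compound 3 (0.37 log units; beyond the scatter), so among these three compounds only compound 1 stands apart, at the high-number end. No measurement beyond the growth read-out bears on this result, and no cause can be given for it.

As far as these compounds go, whether an unsubstituted phenyl or a phenyl carrying a methoxy group or a nitrile on the same nitrogen would read with compound 2 and compound 3 or with compound 1 remains open. Also open, from the compounds shown here alone, is how a phenyl carrying an amine or a carboxylic acid would read here.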